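This account rests on a few compounds, and the source may have more. Where it says the series, first, only, none or still open, it means among the compounds named here.

Compound 1 `O=C(NC/C=C\Cn1ccc(=O)[nH]c1=O)c1ccccc1` is the starting point of this short series. In a functional assay on HEp-2 cells (Homo sapiens) for cytotoxicity, read by MTT assay, with a stated time of 72 h (a lower number here means a stronger inhibitor, a higher number a weaker inhibitor), compound 1 gives > 100000 nM, which is a limit of the assay rather than a number. Going by the values given here, compound 2 `O=C(NC/C=C\Cn1cc(F)c(=O)[nH]c1=O)c1ccccc1` differs from it only by a fluoro in place of hydrogen on an aromatic carbon, and in this assay compound 2 gives 87500 nM, the only plain number in the set. The step of an at least 1.1-fold lower number from compound 1 to compound 2 (0.05 log units; that floor lies within the scatter) is small and rests on a limit, (the limit of > 100000 nM in this assay, at which 1 of the 2 values shown sits), so compound 2 stands as the single firm point. Compound 3 `Cc1cn(C/C=C\CNC(=O)c2ccccc2)c(=O)[nH]c1=O` carries a methyl in place of fluoro on an aromatic carbon. Among the compounds with values here, only the step from compound 1 to compound 2 bears on this change, and it is too small to set a direction, so no step beyond the scatter is expected in this assay for the move a 1.1-fold higher number from compound 2 to compound 3 (0.06 log units; within the scatter). For compound 3 the expected value is therefore 100000 nM, between 40000 nM and 250000 nM.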

Compound 3, half-maximal inhibitory concentration: > 100000 nM
Compound 3 gave a limit, no number; the forecaster's own chance of this, stated with the estimate: 50%; the middle value sits exactly at the limit.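

Going by these compounds alone, at this position on the shared core, methyl in place of fluoro gives an at least 1.1-fold higher number from compound 2 to compound 3 (0.05 log units; that floor lies within the scatter) in this assay, so this change, like the earlier one, shows no step that clears the scatter. The new result adds a second limit, so the compounds with hydrogen and methyl at this position carry no plain number, and only compound 2 does: the limit of > 100000 nM in this assay, at which 2 of the 3 values shown sit. Both ends of the step between compound 1 and compound 3 are limits, and that step cannot be read.

The compounds shown carry only hydrogen, fluoro and methyl at this position, so it remains open whether any group placed here can give a step beyond the scatter. On these data alone, how an amine, a carboxylic acid or a longer chain such as ethyl would read in this assay also stays open.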